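A few compounds are considered here, and "the series" means these few. Any claim that something is new, unique, unknown or untested is made for them only; others in the source may bear on it.

Notes on the series in a toxicity assay on THP-1 cells (Homo sapiens) for inhibition; a higher number here means that more compound is tolerated, a lower number that less compound is tolerated.

Compound 2 `COc1ccc(-c2cnc(NC(=O)c3cccc(C#N)c3)n2C)cc1` stands at the limit of the assay: in this assay compound 2 gives > 100000 nM, which is a limit and not a number. Compound 1 `COc1ccc(-c2cnc(NC(=O)c3cccc([N+](=O)[O-])c3)n2C)cc1` stops at the same kind of limit; in this assay compound 1 gives > 100000 nM, again a limit. Compound 3 `Cc1ccc(C(=O)Nc2ncc(-c3ccccc3)n2C)cc1` sits at a lower limit; in this assay compound 3 gives > 50000 nM, also a limit. So compound 2 stands where the whole series stands: every value shown is a limit, and no compound can be ordered against another. For the measured compounds named here, the one measured step, a step that the two limits leave unreadable from compound 1 to compound 2, cannot be read, as the limit of > 100000 nM in this assay, at which 2 of the 3 values shown sit, records for two of the three values and the limit of > 50000 nM in this assay, at which 1 of the 3 values shown sits, for the third.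

Compound 4 `COc1ccc(-c2cnc(NC(=O)c3ccn[nH]3)n2C)cc1` differs from compound 2 by 1H-pyrazol-5-yl in place of 3-cyanophenyl on a carbonyl carbon. Going by the values given here, no measured step bears on this change, and the single step is itself unreadable. The step expected in this assay is therefore a step that the limit leaves unreadable from compound 2 to compound 4, none beyond the scatter. Compound 4 is estimated at 150000 nM, with a range of 50000 nM to 500000 nM, and the assay is expected most likely to report only a limit again.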

Compound 4, half-maximal cytotoxic concentration: > 100000 nM
Compound 4: only a limit was reported; the forecaster's own chance of this, stated with the estimate: 80%; the middle value does not contradict the limit.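

In this assay compound 4 gives > 100000 nM, which is a limit and not a number. Compound 2 also stands at a limit, so the step between compound 2 and compound 4 cannot be read. The compounds shown leave open at what concentration any of them becomes toxic, and whether exchanging 3-cyanophenyl for 1H-pyrazol-5-yl changes that concentration.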